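Adding a methyl to the side chain: does tolerability hold?

This account rests on a few compounds, and the source may have more. Where it says the series, first, only, none or still open, it means among the compounds named here.

Compound 1 `Cc1c(Cc2c(Cl)cccc2Cl)nc(SCC(=O)c2ccccc2)[nH]c1=O` gives > 60000 nM in an ADME assay on MT4 cells (Homo sapiens) for cytotoxicity, read by MTT assay (a higher number here means that more compound is tolerated, a lower number that less compound is tolerated), a limit of the assay rather than a number.
Compound 2 `CCc1c(Cc2c(Cl)cccc2Cl)nc(SCC(=O)c2ccccc2)[nH]c1=O` gives > 52000 nM in this assay, again a limit.
Compound 3 `CC(C)c1c(Cc2c(F)cccc2Cl)nc(SCC(=O)c2ccc(F)cc2)[nH]c1=O` gives > 56000 nM in this assay, also a limit.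

Compound 2 differs from compound 1 by methyl in place of hydrogen on a saturated chain carbon bound to an aromatic carbon. The measured step that the two limits leave unreadable from compound 1 to compound 2 cannot be read, because both values are limits, the limit of > 60000 nM in this assay, at which 1 of the 3 values shown sits, and (the limit of > 52000 nM in this assay, at which 1 of the 3 values shown sits). Compound 4 `CCC(C)c1c(Cc2c(F)cccc2Cl)nc(SCC(=O)c2ccc(F)cc2)[nH]c1=O` differs from compound 3 by methyl in place of hydrogen on a saturated chain carbon, two bonds along the chain from an aromatic carbon. This is the same kind of change, but the place differs: in compound 2 the new methyl sits on a saturated chain carbon bound to an aromatic carbon, in compound 4 two bonds along the chain from an aromatic carbon. The difference between the two cores is not broken down here. Since compound 3 gives only a limit, (the limit of > 56000 nM in this assay, at which 1 of the 3 values shown sits), compound 4 is expected to give a step that the limit leaves unreadable from compound 3 to compound 4. Compound 4 is expected to give about 60000 nM, most likely again a limit.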

Compound 4, half-maximal cytotoxic concentration: > 54000 nM
Compound 4: no number, only a limit; the forecaster's own chance of this, stated with the estimate: 80%; the middle value is on the limit's open side.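

Compound 3 and compound 4 each give only a limit in this assay, so no step can be read between them. The compounds shown leave open at what concentration any of them harms the cells, and whether the added methyl changes that.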